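A few compounds are considered here, and "the series" means these few. Any claim that something is new, unique, unknown or untested is made for them only; others in the source may bear on it.

Measured compounds:
- Compound 1, `COc1c(NS(=O)(=O)c2ccc(F)cc2)cc(-c2ccc3nc(NC4CC4)sc3n2)cc1C(N)=O`, gives 35700 nM in a functional assay on HCT-116 cells (Homo sapiens) for antiproliferative activity, read by MTT assay, with a stated time of 72 h; on this read-out lower numbers stand for stronger inhibition and higher numbers for weaker inhibition.
- Compound 2, `COc1c(NS(=O)(=O)c2ccc(F)cc2)cc(-c2ccc3nc(NC(C)=O)sc3c2)cc1C(N)=O`, gives 1950 nM in this assay.
- Compound 3, `COc1c(NS(=O)(=O)C2CC2)cc(-c2ccc3nc(NC(C)=O)nn3c2)cc1C(N)=O`, gives 36300 nM in this assay.

Among these three numbers, compound 1 stands second highest, so it is one of the weaker inhibitors here. Its nearest neighbour is compound 3, whose number lies within the usual scatter of compound 1, so the two cannot be told apart. For the measured compounds named here, compound 2 sits far below both, beyond the scatter, though it differs from compound 1 in more than one place and no single step links them.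

Compound 4, `COc1c(NS(=O)(=O)c2ccc(F)cc2)cc(-c2ccc3nc(NC(=O)C4CC4)sc3n2)cc1C(N)=O`, has not yet been measured. It differs from compound 1 in one place: cyclopropylcarbonyl in place of cyclopropyl on a nitrogen on an aromatic ring. Put more simply, the nitrogen on the shared core now carries cyclopropylcarbonyl rather than cyclopropyl, so the amine becomes an amide. Going by the values given here, no measured pair shows exactly this change. The only hint is that compound 2, which also carries an acyl group on its ring nitrogen, gives the lowest number shown, but its core and attachment point differ, so that hint is weak.

The expectation for compound 4 is a moderate move toward a lower number, a 3.0-fold lower number from compound 1 to compound 4 (0.47 log units; beyond the scatter), with considerable uncertainty. The estimated value for compound 4 in this assay is 12000 nM, with a range from 4000 nM to 40000 nM.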

Compound 4, half-maximal inhibitory concentration: 2500 nM
Estimate against measurement, compound 4: 4.8-fold (0.68 log units) above; measured number below the stated range.
By their numbers in this assay, from the lowest: compounds 2 and 4 (each within the scatter of the next); then compounds 1 and 3 (each within the scatter of the next).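

In this assay, placing cyclopropylcarbonyl in place of cyclopropyl on a nitrogen on an aromatic ring gives a 14-fold lower number from compound 1 to compound 4 (1.15 log units; beyond the scatter) and counts as a large step. For the compounds shown here, this shows that the group on this nitrogen matters for the read-out, which no earlier pair could show. The cyclopropyl ring stays in both compounds, so the step comes with the added carbonyl, which turns the amine into an amide, but nothing shown explains why the step is so large.

This single pair leaves open whether other groups on this nitrogen, such as a benzoyl group, a longer chain like butanoyl or a plain unsubstituted amine, would give a similar number. It also leaves open whether the same change would give a step of similar size on a different core.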